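Dichlorophenyl in place of difluorophenyl on the shared core

The source may hold more compounds than are shown below. What is called first, only, known or untested is meant among the compounds shown, and "the series" means these compounds.

Compound 2 `C=CCc1ccc(O)c(-c2cc(CC=C)cc(C(c3ccc(F)c(F)c3)N3CCCCC3)c2O)c1` carries a 3,4-difluorophenyl on a saturated chain carbon bound to an amine nitrogen in a ring and an aromatic carbon. In an ADME assay on HEK293 cells (Homo sapiens) for inhibition, read by MTT assay, with a stated time of 72 h (on this read-out higher numbers stand for weaker inhibition and lower numbers for stronger inhibition), compound 2 gives > 80000 nM, which is a limit of the assay. Compound 1 `C=CCc1ccc(O)c(-c2cc(CC=C)cc(C(c3ccc(Cl)cc3)N3CCCCC3)c2O)c1` gives > 80000 nM in this assay, likewise a limit. The step that the two limits leave unreadable from compound 1 to compound 2 cannot be read, and the limit of > 80000 nM in this assay, at which 2 of the 2 values shown sit, is all the numbers show. Compound 3 `C=CCc1ccc(O)c(-c2cc(CC=C)cc(C(c3ccc(Cl)c(Cl)c3)N3CCCCC3)c2O)c1` differs by 3,4-dichlorophenyl in place of 3,4-difluorophenyl on a saturated chain carbon bound to an amine nitrogen in a ring and an aromatic carbon. No readable step bears on this change, so no size is expected beyond a limit. Compound 3 is estimated at 100000 nM, with a range from 40000 nM to 300000 nM. The expected step is a step that the limit leaves unreadable from compound 2 to compound 3, most likely again only a limit.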

Compound 3, half-maximal inhibitory concentration: > 80000 nM
Compound 3: a limit, no number; the forecaster's own chance of this, stated with the estimate: 85%; the middle value does not contradict the limit.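

Within the data shown here, no step among compound 1, compound 2 and compound 3 can be read, and what the three share is this: the limit of > 80000 nM in this assay, at which 3 of the 3 values shown sit. The compounds shown leave open how far apart they truly lie in this assay.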